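This account rests on a few compounds, and the source may have more. Where it says the series, first, only, none or still open, it means among the compounds named here.

Compound 1 `OCc1cc(O)c(O)c(Br)c1`: 51500 nM
Compound 2 `CCOCc1cc(O)c(O)c(Br)c1`: 35100 nM

In a functional assay on DLD-1 cells (Homo sapiens) for cytotoxicity, read by MTT assay, with a stated time of 96 h (on this read-out lower numbers stand for stronger inhibition and higher numbers for weaker inhibition), compound 2 has the lower of the two numbers shown, but the step of a 1.5-fold lower number from compound 1 to compound 2 (0.17 log units; within the scatter) lies within the usual scatter, so the two compounds cannot really be told apart. Compound 3 `CCCOCc1cc(O)c(O)c(Br)c1` differs from compound 2 by methyl in place of hydrogen on a saturated chain carbon, two bonds along the chain from an oxygen on a saturated carbon. Within the data shown here, the only measured step that bears on this change is the earlier lengthening of the same chain, a 1.5-fold lower number from compound 1 to compound 2 (0.17 log units; within the scatter), which stayed within the scatter; a further lengthening is therefore expected to give no step beyond the scatter in this assay. Compound 3 is expected to give about 30000 nM, with a range of 14000 nM to 65000 nM. The expected step is a 1.2-fold lower number from compound 2 to compound 3 (0.07 log units; within the scatter).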

Compound 3, half-maximal inhibitory concentration: 26300 nM
Beside the measured number, compound 3's estimate is 1.1-fold (0.06 log units) above it; low and high end bracket the measured number.
By their numbers in this assay, from the lowest: compounds 3, 2 and 1 (each within the scatter of the next).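

In this assay going from ethoxy to propoxy gives a 1.3-fold lower number from compound 2 to compound 3 (0.13 log units; within the scatter) and putting propyl in place of the hydrogen on the oxygen gives a 2.0-fold lower number from compound 1 to compound 3 (0.29 log units; within the scatter) overall. So a second lengthening of this chain stays within the scatter, and even the two lengthenings taken together do not step beyond it. Nothing available explains these small steps. As far as these compounds go, whether a longer chain such as butyl would step beyond the scatter remains open. So does the effect of a chain ending in an amine or a carboxylic acid.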